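This account rests on a few compounds, and the source may have more. Where it says the series, first, only, none or still open, it means among the compounds named here.

Compound 1 `CC(C(=O)NOCc1ccccc1)N1C(=O)S/C(=C\c2ccccc2)C1=O` in an ADME assay on RAW264.7 cells (Mus musculus) for cytotoxicity, read by neutral red uptake, with a stated time of 24 h (on this read-out higher numbers stand for lower toxicity in this test and lower numbers for higher toxicity in this test), gives > 128000 nM, a limit of the assay rather than a number.
Compound 2 `C=CCONC(=O)C(C)N1C(=O)S/C(=C\c2ccccc2)C1=O` in this assay gives > 128000 nM, again a limit.
Compound 3 `CCCC/C=C1\SC(=O)N(CC(=O)NOCc2ccccc2)C1=O` in this assay gives > 128000 nM, also a limit.

The change from compound 1 to compound 2 is vinyl in place of phenyl on a saturated chain carbon bound to an oxygen, and in this assay it gives a step that the two limits leave unreadable from compound 1 to compound 2. The cores of compound 1 and compound 3 differ; that difference is not broken down here. Compound 4 `C=CCONC(=O)CN1C(=O)S/C(=C\CCCC)C1=O`, not yet measured, arises from compound 3 by vinyl in place of phenyl on a saturated chain carbon bound to an oxygen, the same change seen from compound 1 to compound 2. All that is known about the series in this assay is the limit of > 128000 nM in this assay, at which 3 of the 3 values shown sit, so no readable step is available to carry over. From compound 3 to compound 4 in this assay the expected step is a step that the limit leaves unreadable from compound 3 to compound 4, resting on compound 1 and compound 2 sitting at the limit of > 128000 nM in this assay, at which 3 of the 3 values shown sit. For compound 4 in this assay the estimate is 200000 nM, with a range from 64000 nM to 1000000 nM.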

Compound 4, half-maximal cytotoxic concentration: > 128000 nM
Compound 4 gave a limit, no number; the forecaster's own chance of this, stated with the estimate: 85%; the middle value lies beyond the limit too.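

Compound 3 and compound 4 both sit at a limit in this assay, so no step between them can be read: the limit of > 128000 nM in this assay, at which 4 of the 4 values shown sit.

The compounds shown leave open whether vinyl in place of phenyl changes this read-out at all.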